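Benzyl for Methyl on a Selenium-Bridged Diamide Core

This account rests on a few compounds, and the source may have more. Where it says the series, first, only, none or still open, it means among the compounds named here.

Measured compounds:
- compound 1 `C[Se]/C(=N\C(=O)c1cc2ccccc2s1)NC(=O)c1cc2ccccc2s1`: 89600 nM
- compound 2 `C[Se]/C(=N\C(=O)c1ccno1)NC(=O)c1ccno1`: > 100000 nM
- compound 3 `O=C(/N=C(/NC(=O)c1cc(-c2ccccc2)nc2ccccc12)[Se]Cc1ccccc1)c1cc(-c2ccccc2)nc2ccccc12`: 88900 nM

In a functional assay on K562 cells (Homo sapiens) for cytotoxicity, read by MTT assay, with a stated time of 72 h (a lower number here means that less compound is tolerated, a higher number that more compound is tolerated), compound 1 gives 89600 nM, and compound 3 sits at 88900 nM, a number within the usual scatter of compound 1. For compound 2 the assay reports only a limit, > 100000 nM, which is the limit of > 100000 nM in this assay, at which 1 of the 3 values shown sits. Compound 4 `O=C(/N=C(/NC(=O)c1cc2ccccc2s1)[Se]Cc1ccccc1)c1cc2ccccc2s1` carries the change (phenyl in place of hydrogen on a saturated chain carbon bound to a selenium atom), a phenyl in place of hydrogen on the saturated chain carbon bound to selenium. Compound 3 carries the benzyl on another core and matches compound 1 closely, so no shift beyond the scatter is expected; the expected step of a 1.0-fold higher number from compound 1 to compound 4 (0.00 log units; within the scatter) is none beyond the scatter. Compound 4 is therefore estimated at 90000 nM, between 45000 nM and 180000 nM.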

Compound 4, concentration lethal to 50% of the cells: 70600 nM
For compound 4 the middle estimate is 1.3-fold (0.11 log units) above the measured one; the range from low to high includes it.
By their numbers in this assay, from the lowest: compounds 4, 3 and 1 (each within the scatter of the next). At a limit, above all of these: compound 2.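

In this assay, the change from methyl to benzyl, with phenyl in place of hydrogen on a saturated chain carbon bound to a selenium atom, can now be read on a single core, and it gives a 1.3-fold lower number from compound 1 to compound 4 (0.10 log units; within the scatter). On the core of compound 1, this position therefore takes the added phenyl without a step beyond the scatter. Nothing among the data shown bears on the reason for this result.

The compounds shown leave open whether an amine, a carboxylic acid or a longer chain in place of the benzyl would give a step beyond the scatter. They also leave open whether methyl to benzyl reads the same on the cores of compound 2 and compound 3.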